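Terminal amine ring variation on a shared core

The source may report more compounds than this note shows. Statements on the series, on what has been measured and on what is new or still open speak of the compounds shown alone.

Measured in a functional assay on HT-29 cells (Homo sapiens) for inhibition, read by MTT assay, with a stated time of 72 h; a lower number here means a stronger inhibitor, a higher number a weaker inhibitor:
compound 1 `COc1cc2c(Oc3ccc(NC(=O)c4nn(-c5ccccc5C(F)(F)F)c(=O)cc4C)cc3F)ccnc2cc1OCCCN1CCCC1`: 140 nM
compound 2 `COc1cc2c(Oc3ccc(NC(=O)c4nn(-c5ccccc5C(F)(F)F)c(=O)cc4C)cc3F)ccnc2cc1OCCCN1CCCCC1`: 170 nM

Two compounds only, on one core. For the measured compounds named here, compound 2 stands with the single other number, compound 1, inside the usual scatter: a 1.2-fold higher number from compound 1 to compound 2 (0.08 log units; within the scatter). Nothing in the pair separates one from the other.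

Compound 3 `COc1cc2c(Oc3ccc(NC(=O)c4nn(-c5ccccc5C(F)(F)F)c(=O)cc4C)cc3F)ccnc2cc1OCCCN1CCN(C)CC1` is the next member. It differs from compound 2 in one place: 4-methylpiperazin-1-yl in place of piperidin-1-yl on a saturated chain carbon, three bonds along the chain from an oxygen on an aromatic ring.

Going by the values given here, only one measured step bears on this change, the ring-size exchange from compound 1 to compound 2, a 1.2-fold higher number from compound 1 to compound 2 (0.08 log units; within the scatter), which stayed within the scatter. Among the compounds with values here, no measured pair exchanges a ring carbon for a methyl-bearing nitrogen at this position, so the expectation rests on that single step and on the shared remainder of the molecule, which is unchanged.

The expected step is therefore none beyond the scatter: a 1.2-fold higher number from compound 2 to compound 3 (0.07 log units; within the scatter). For compound 3 in this assay the estimate is 200 nM, with a range from 90 nM to 450 nM.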

Compound 3, half-maximal inhibitory concentration: 170 nM
Compound 3: the middle estimate sits 1.2-fold (0.07 log units) above what was measured; measured number inside the range.
By their numbers in this assay, from the lowest: compounds 1, 2 and 3 (each within the scatter of the next).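

In this assay, 4-methylpiperazin-1-yl in place of piperidin-1-yl gives no change at the digits printed from compound 2 to compound 3 (within the scatter) and, set against pyrrolidin-1-yl, gives a 1.2-fold higher number from compound 1 to compound 3 (0.08 log units; within the scatter) as the second new step. The earlier pair covered only a change of ring size among rings with 1 hetero atom, whereas this result extends the comparison to a six-membered ring with 2 hetero atoms, one of them bearing a methyl group, at the same place on a saturated chain carbon, three bonds along the chain from an oxygen on an aromatic ring, and the three terminal rings remain unseparated in this cell assay. No supporting measurement is available here to account for this sameness of the numbers.

Still open, on these data alone, is whether the same flat reading extends to a morpholin-4-yl ring, an open-chain dimethylamino group or a terminal carboxylic acid at this position. Also open, as far as these compounds go, is whether a chain shorter or longer than the 3-(4-methylpiperazin-1-yl)propyl chain would keep the numbers together, and whether these terminal rings stay inseparable in any other assay.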